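Notes on the ester series from compound 1 to compound 4

The compounds below may be only part of what the source reports. "The series", "measured", "known", "first", "only" and "open" are said of these compounds alone.

Compound 1 `COc1cccc(C(=O)Oc2cc3c(cc2C)[C@@H](C(C)C)CC=C3C)c1` carries a methoxy group on the ester ring of the shared core and is recorded in a functional assay on HCT-15 cells (Homo sapiens) for antiproliferative activity, read by sulforhodamine B assay, with a stated time of 48 h, tested at 50 uM (on this read-out higher numbers stand for more inhibition at the one concentration tested (going by the name of the read-out) and lower numbers for less inhibition), as "not active" (no number reported), so no single number places it. The other esters give numbers: compound 2 `CC1=CC[C@H](C(C)C)c2cc(C)c(OC(=O)Nc3ccccc3)cc21` gives 92% and compound 3 `CC1=CC[C@H](C(C)C)c2cc(C)c(OC(=O)c3ccc(Cl)cc3)cc21` gives 47.4%. Within the data shown here, the only single-change step, a number 44.6 percentage points lower from compound 2 to compound 3 (beyond the scatter), swaps the group on the carbonyl carbon, not a substituent on the aromatic ring, so it does not bear directly on the change to compound 4 `CC1=CC[C@H](C(C)C)c2cc(C)c(OC(=O)c3cccc(C(F)(F)F)c3)cc21`: trifluoromethyl in place of methoxy on an aromatic carbon. With no number for compound 1 and compound 3 at 47.4%, compound 4 is expected to land low to moderate, and its estimate is 30%, between 5% and 60%.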

Compound 4, a percentage reported as inhibition, at one concentration (the size of the read-out at that concentration, not a potency): 15%
The estimate for compound 4 lay 15 percentage points above the measured number; the measured number falls inside the stated range.
By their numbers in this assay, from the lowest: compound 4; then compound 3; then compound 2.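

No step can be read from compound 1 to compound 4: compound 1 stands as "not active" (no number reported), while compound 4 gives 15%. The compounds shown leave open how trifluoromethyl compares numerically with methoxy at this place. No measurement here accounts for the value of compound 4.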